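This account rests on a few compounds, and the source may have more. Where it says the series, first, only, none or still open, it means among the compounds named here.

The measured compounds and their values:

compound 1, `COc1ccc([C@@H]2C/C(=N/OCc3cn(-c4ccccc4CO)nn3)c3cc(CC=C(C)C)c(OC)cc3O2)cc1`: 100%
compound 2, `COc1ccc([C@@H]2C/C(=N/OCc3cn(-c4ccc(NC(=O)c5ccccc5)cc4)nn3)c3cc(CC=C(C)C)c(OC)cc3O2)cc1`: 8%
compound 3, `COc1ccc([C@@H]2C/C(=N/OCc3cn(-c4ccc(C(N)=O)cc4)nn3)c3cc(CC=C(C)C)c(OC)cc3O2)cc1`: 100%

In a functional assay on HCT-116 cells (Homo sapiens) for inhibition, read by sulforhodamine B assay, with a stated time of 48 h, tested at 50 uM (a lower number here means less inhibition of growth, a higher number more inhibition of growth at the concentration tested), compound 3 stands level with compound 1, the two together giving the highest of the three numbers, while the gap to compound 2 is wide: a number 92 percentage points higher from compound 2 to compound 3 (beyond the scatter). The step of no change at the digits printed from compound 1 to compound 3 (within the scatter) shows that exchanging one substituted phenyl on the aromatic nitrogen for another left the number unchanged.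

Compound 4, `COc1ccc([C@@H]2C/C(=N/OCc3cn(-c4ccc(NC(C)=O)cc4)nn3)c3cc(CC=C(C)C)c(OC)cc3O2)cc1`, is reached from compound 3 by one change: acetamido in place of carbamoyl on an aromatic carbon. Within the data shown here, two measured steps bear on it. The step from compound 2 to compound 3 shows that an amide joined through its nitrogen on that aromatic carbon, with a phenyl on the carbonyl, went with a much lower number than carbamoyl. Acetamido is again an amide joined through its nitrogen, but carries a methyl rather than a phenyl, so the data leave the outcome open between the two measured extremes. Compound 4 is therefore expected to give 65% in this assay, within 15% to 100%. This expectation corresponds to an estimated step of a number 35 percentage points lower from compound 3 to compound 4 (beyond the scatter).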

Compound 4, percent growth inhibition at one concentration: 6%
Beside the measured number, compound 4's estimate is 59 percentage points above it, outside the stated range (below it).
By their numbers in this assay, from the lowest: compounds 4 and 2 (each within the scatter of the next); then compounds 1 and 3 (each within the scatter of the next).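

In this assay, among these compounds, the place on the aromatic carbon para to a large group proves far less forgiving than the earlier compounds could show, since acetamido in place of carbamoyl gives a number 94 percentage points lower from compound 3 to compound 4 (beyond the scatter). The low number of compound 2 therefore does not depend on the phenyl on its carbonyl: methyl in its place gives a number 2 percentage points lower from compound 2 to compound 4 (within the scatter), so both amides joined through their nitrogen stay together at the low end. Nor does every substituted phenyl on the aromatic nitrogen match 2-(hydroxymethyl)phenyl, as 4-acetamidophenyl in its place gives a number 94 percentage points lower from compound 1 to compound 4 (beyond the scatter).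

On these data alone, whether an amine or a carboxylic acid on that aromatic carbon would stand with carbamoyl or with the two amides remains open. Nothing given here accounts for the gap between carbamoyl and the amides joined through nitrogen.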